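The source may hold more compounds than are shown below. What is called first, only, known or untested is meant among the compounds shown, and "the series" means these compounds.

Measured so far in a functional assay on A549/CDDP cells (Homo sapiens) for antiproliferative activity, read by MTT assay, with a stated time of 72 h; a higher number here means a weaker inhibitor, a lower number a stronger inhibitor:
compound 1 `Cc1nc(C)c(/C=C/C(=O)/C=C/c2ccccc2O)nc1C`: 3900 nM
compound 2 `Cc1nc(C)c(/C=C/C(=O)/C=C/c2ccccc2)nc1C`: 11900 nM

Compound 2 has the higher number of the two, which makes it the weaker inhibitor of this pair. The gap between them is a 3.1-fold higher number from compound 1 to compound 2 (0.48 log units; beyond the scatter). That step lies beyond the scatter but is modest: with hydrogen in place of hydroxy on an aromatic carbon, the result gets weaker.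

The next compound, compound 3 `Cc1nc(C)c(/C=C/C(=O)/C=C/c2ccccc2[N+](=O)[O-])nc1C`, keeps the rest of compound 2 and changes one thing: nitro in place of hydrogen on an aromatic carbon. In words, this is nitro in place of hydrogen on an aromatic carbon. Going by the values given here, only the one measured step bears on this change, and it concerns a hydroxy rather than a nitro, so it is a loose guide. Among the compounds with values here, no nitro compound has been measured yet. Compound 1 at 3900 nM does show that a group on this ring can go with a lower number than hydrogen gives. A modest gain is therefore expected, smaller than the measured step, and the expected step is a 1.8-fold lower number from compound 2 to compound 3 (0.26 log units; within the scatter). Compound 3 is estimated at 6500 nM, with an expected range of 2500 nM to 16000 nM.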

Compound 3, half-maximal inhibitory concentration: 6390 nM
Beside the measured number, compound 3's estimate is 1.0-fold (0.01 log units) above it, within the range that was stated.
By their numbers in this assay, from the lowest: compounds 1, 3 and 2 (each within the scatter of the next, the first and the last beyond it).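

Nitro on this aromatic carbon, ortho to a large group, gives a 1.9-fold lower number from compound 2 to compound 3 (0.27 log units; within the scatter) and a 1.6-fold higher number from compound 1 to compound 3 (0.21 log units; within the scatter) in this assay, so compound 3 cannot be told apart from either of the other two compounds. Going by these compounds alone, compounds 1 and 2 remain the only pair separated beyond the scatter, and a third group at this place does not extend that pair into a clear ranking of the three groups. Nitro carries 0 hydrogen-bond donors, yet compound 3 is not separated from the hydroxy compound 1, so these numbers do not show that a donor is needed here, and no measurement is available to explain any of these numbers.

Still open, going by these compounds, is whether nitro really differs from hydrogen or hydroxy at all, a question that steps of this size cannot settle. Also open, on these data alone, is how an amine, a methoxy group or a fluorine atom would read at this same place, and whether hydroxy or nitro elsewhere on the ring would give similar numbers.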